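The compounds below may be only part of what the source reports. "The series", "measured", "known", "first", "only" and "open" are said of these compounds alone.

In a functional assay on HepG2 cells (Homo sapiens) for inhibition, read by MTT assay, with a stated time of 48 h (on this read-out lower numbers stand for stronger inhibition and higher numbers for weaker inhibition), compound 1 `CCOC(=O)C1=C(N/N=C(/C#N)C(=O)OCC)Nc2[nH]nc(C)c2C1c1ccc(N(C)C)cc1` gives 46400 nM and compound 2 `CCOC(=O)C1=C(N/C=N/c2nnc(S(N)(=O)=O)s2)Nc2[nH]nc(C)c2C1c1ccc(N(C)C)cc1` gives 38100 nM, while compound 3 `CCOC(=O)C1=C(N/N=C(/Cl)C#N)Nc2[nH]nc(C)c2C1c1ccc(N(C)C)cc1` gives 23600 nM and so stands within the scatter of both. Compound 4 `CCOC(=O)C1=C(N/N=C(/C(C)=O)C(=O)OCC)Nc2[nH]nc(C)c2C1c1ccc(N(C)C)cc1` differs from compound 3 on an amine nitrogen, with a group of 10 heavy atoms (6 carbon, 1 nitrogen, 3 oxygen; no ring) in place of a group of 5 heavy atoms (2 carbon, 2 nitrogen, 1 chlorine; no ring), on an amine nitrogen as the change. Three earlier swaps at this nitrogen all stayed within the scatter, with a 1.2-fold lower number from compound 1 to compound 2 (0.09 log units; within the scatter) and a 2.0-fold lower number from compound 1 to compound 3 (0.29 log units; within the scatter) and a 1.6-fold lower number from compound 2 to compound 3 (0.21 log units; within the scatter) as the steps seen. No step beyond the scatter is therefore expected in this assay for this new swap. The entering group has no ring, like the group of compound 1 with 46400 nM as its value, so the estimate sits near that value. The expected step is a 1.6-fold higher number from compound 3 to compound 4 (0.21 log units; within the scatter) and would stay within the scatter. Compound 4 is estimated at 38000 nM with an expected range from 18000 nM to 78000 nM in this measurement.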

Compound 4, half-maximal inhibitory concentration: > 100000 nM
Compound 4 was reported as a limit; the forecaster's own chance of this, stated with the estimate: 5%; middle value at least 2.6-fold (0.42 log units) from the limit.
By their numbers in this assay, from the lowest: compounds 3, 2 and 1 (each within the scatter of the next). At a limit, above all of these: compound 4.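

In this assay, this amine nitrogen turns out to be less tolerant than the earlier swaps suggested, since a change here can move the read-out beyond the scatter: an at least 4.2-fold higher number from compound 3 to compound 4 (0.62 log units; beyond the scatter), an at least 2.6-fold higher number from compound 2 to compound 4 (0.41 log units; beyond the scatter) and an at least 2.1-fold higher number from compound 1 to compound 4 (0.33 log units; beyond the scatter). The last of these steps is the cleanest comparison, as acetyl in place of cyano on a carbon with a double bond to nitrogen is the only difference. Compound 4 is reported only as a limit: the limit of > 100000 nM in this assay, at which 1 of the 4 values shown sits.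

The true size of these steps stays unknown, and the values give no reason for them. As far as these compounds go, whether a methyl or a carboxylic acid in place of the acetyl would stay within the scatter of compound 1 also remains open.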